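A few compounds are considered here, and "the series" means these few. Any claim that something is new, unique, unknown or untested is made for them only; others in the source may bear on it.

Measured compounds:
Compound 1, `COc1ccc2nc(C)cc(OCC(=O)NCc3cc(C)cc(C)c3)c2c1`, gives > 100000 nM in a toxicity assay on HepG2 cells (Homo sapiens) for inhibition, read by CellTiter-Glo, with a stated time of 48 h (on this read-out lower numbers stand for stronger inhibition and higher numbers for weaker inhibition), a limit rather than a number.
Compound 2, `COc1ccc2nc(C)cc(OCC(=O)Nc3ccccc3)c2c1`, gives 39800 nM in this assay.

Among the compounds with values here, compound 2 therefore stands as the only compound with a measured number in this assay; the other entry is a limit, (the limit of > 100000 nM in this assay, at which 1 of the 2 values shown sits). Within the data shown here, the single measured step runs an at least 2.5-fold lower number from compound 1 to compound 2 (0.40 log units; beyond the scatter), so the smaller amide substituent gives the stronger inhibition of the two.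

Compound 3, `COc1ccc2nc(C)cc(OCC(=O)Nc3cccc(C)c3)c2c1`, is not yet measured. It differs from compound 2 by methyl in place of hydrogen on an aromatic carbon. This change adds a single methyl to the phenyl, a much smaller addition than the 3,5-dimethylbenzyl that compound 1 carries, so the measured step from compound 1 to compound 2 bears on it only loosely and points, if anything, toward a somewhat higher number. The expected step is a 1.1-fold higher number from compound 2 to compound 3 (0.05 log units; within the scatter), within the scatter of the assay. Compound 3 is estimated at 45000 nM in this assay, within a range from 15000 nM to 120000 nM.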

Compound 3, half-maximal inhibitory concentration: 39800 nM
Estimate against measurement, compound 3: 1.1-fold (0.05 log units) above, within the range that was stated.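

In this assay, methyl in place of hydrogen on an aromatic carbon, meta to a large group, gives no change at the digits printed from compound 2 to compound 3 (within the scatter), so at this position the phenyl takes the added methyl with no change that the assay can separate. The comparison with the 3,5-dimethylbenzyl amide shows an at least 2.5-fold lower number from compound 1 to compound 3 (0.40 log units; beyond the scatter), which matches the earlier step, an at least 2.5-fold lower number from compound 1 to compound 2 (0.40 log units; beyond the scatter), so adding one methyl to the phenyl does not bring compound 3 back toward compound 1. Both of these steps are bounds rather than sizes, and compound 1 is the compound whose entry is a limit of the assay: the limit of > 100000 nM in this assay, at which 1 of the 3 values shown sits.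

The compounds shown leave open whether this result holds at other positions of the phenyl, or for other groups at the same position, such as chlorine, methoxy or a carboxylic acid. They also leave open whether the weaker inhibition of compound 1 goes with the methylene link of the benzyl or with its two methyl groups, as an unsubstituted benzyl amide would be needed to separate the two.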